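Loss of a Hydroxy Group in Two Closely Related Cores

The source may report more compounds than this note shows. Statements on the series, on what has been measured and on what is new or still open speak of the compounds shown alone.

In a functional assay on MCF7 cells (Homo sapiens) for cytotoxicity (on this read-out lower numbers stand for stronger inhibition and higher numbers for weaker inhibition), compound 1 `Nc1ccc(-c2nc3cc(O)ccc3s2)cc1Cl` gives 60600 nM. Compound 2 `Nc1ccc(-c2nc3ccccc3s2)cc1Cl` differs from it by hydrogen in place of hydroxy on an aromatic carbon, and the step of an at least 60000-fold lower number from compound 1 to compound 2 (4.78 log units; beyond the scatter) runs down to the limit of < 1 nM in this assay, at which 1 of the 3 values shown sits. In this assay compound 2 reports only a limit, < 1 nM. Compound 3 `Cc1cc(-c2nc3cc(O)ccc3s2)ccc1N` carries a different core, set apart from that of compound 1 by methyl in place of chloro on an aromatic carbon; in this assay compound 3 gives 78700 nM, and the step of a 1.3-fold higher number from compound 1 to compound 3 (0.11 log units; within the scatter). Compound 4 `Cc1cc(-c2nc3ccccc3s2)ccc1N` stands to compound 3 as compound 2 stands to compound 1, by hydrogen in place of hydroxy on an aromatic carbon, the same change in the same surroundings. The step from compound 3 to compound 4 is expected to be about as large, a 52000-fold lower number from compound 3 to compound 4 (4.72 log units; beyond the scatter), an expectation resting on the step of an at least 60000-fold lower number from compound 1 to compound 2 (4.78 log units; beyond the scatter). Compound 4 is therefore estimated at 1.5 nM, expected to fall between 0.3 nM and 40 nM.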

Compound 4, half-maximal inhibitory concentration: < 1 nM
Compound 4: a limit, no number; the forecaster's own chance of this, stated with the estimate: 45%; middle value at least 1.5-fold (0.17 log units) away from the limit.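

In this assay compound 4 gives < 1 nM, which is a limit of the assay and not a number. Hydrogen in place of hydroxy on an aromatic carbon thus gives a large step on the second core as well, an at least 78000-fold lower number from compound 3 to compound 4 (4.89 log units; beyond the scatter), and it stands beside the earlier step as follows: the same change on two cores in this assay, an at least 60000-fold lower number (4.78 log units; beyond the scatter) from compound 1 to compound 2 and an at least 78000-fold lower number (4.89 log units; beyond the scatter) from compound 3 to compound 4; the limit leaves it open whether they differ. This does not show that the two steps are equal in size, and the step between compound 2 and compound 4 cannot be read, as both values are limits: the limit of < 1 nM in this assay, at which 2 of the 4 values shown sit.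

The compounds shown leave open how a methoxy group or an amine in place of the hydroxy would read in this assay on either core. They also leave open whether the step carries over to cores with groups other than chloro or methyl, such as a fluoro group.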